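Cytotoxicity notes: amino to methyl on the core

A few compounds are considered here, and "the series" means these few. Any claim that something is new, unique, unknown or untested is made for them only; others in the source may bear on it.

Measured so far in an ADME assay on MRC5 cells (Homo sapiens), read by MTT assay, with a stated time of 3 days; a higher number here means a weaker inhibitor, a lower number a stronger inhibitor:
compound 1, `CN(C)c1ncnc2[nH]cc(Sc3cccs3)c12`, > 150000 nM (a limit of the assay)
compound 2, `Nc1ncnc2[nH]cc(Sc3cccs3)c12`, 136000 nM
compound 3, `c1csc(Sc2c[nH]c3ncnc(-c4cccs4)c23)c1`, 54500 nM

Compound 1 gives only the assay limit here, (the limit of > 150000 nM in this assay, at which 1 of the 3 values shown sits), not a number. Among the two numbers, compound 2 stands highest, with compound 3 nearest at a 2.5-fold lower number from compound 2 to compound 3 (0.40 log units; beyond the scatter). The step of an at least 1.1-fold lower number from compound 1 to compound 2 (0.04 log units; that floor lies within the scatter) is within the scatter, so compound 1 and compound 2 are not separated.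

The next compound is compound 4, `Cc1ncnc2[nH]cc(Sc3cccs3)c12`. It differs from compound 2 thus: methyl in place of amino on an aromatic carbon.

Within the data shown here, two measured steps touch this position. The step of an at least 1.1-fold lower number from compound 1 to compound 2 (0.04 log units; that floor lies within the scatter) shows no separation; the step of a 2.5-fold lower number from compound 2 to compound 3 (0.40 log units; beyond the scatter) is a modest drop. Methyl is neither of those groups, and no measured step replaces amino with methyl, so the expectation leans on the narrow spread of the three values at this position, all in the weak range. A change no larger than the scatter, or a slight lower number, is expected.

For compound 4 the estimate is 110000 nM, within 50000 nM to 200000 nM. This expected figure corresponds to a step of a 1.2-fold lower number from compound 2 to compound 4 (0.09 log units; within the scatter).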

Compound 4, half-maximal inhibitory concentration: 136000 nM
For compound 4 the middle estimate is 1.2-fold (0.09 log units) below the measured one, and the stated range covers the measured number.
By their numbers in this assay, from the lowest: compound 3; then compounds 2 and 4 (each within the scatter of the next). At a limit, above all of these: compound 1.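

Methyl in place of amino gives no change at the digits printed from compound 2 to compound 4 (within the scatter) in this assay, so compound 2 and compound 4 are not separated, although amino carries 1 hydrogen-bond donor and 1 hydrogen-bond acceptor and methyl carries 0 of each. Among these compounds, on this pair, then, the printed number does not follow those counts at this position, which no earlier pair could show. Among the compounds shown here, the other readable step, a 2.5-fold higher number from compound 3 to compound 4 (0.40 log units; beyond the scatter), is modest and leaves compound 3 as the one compound of the series with a number set apart beyond the scatter, with thiophen-2-yl as the only group at this position that has moved the number so far. Dimethylamino offers no number to set against methyl, since an at least 1.1-fold lower number from compound 1 to compound 4 (0.04 log units; that floor lies within the scatter) is only a floor: the limit of > 150000 nM in this assay, at which 1 of the 4 values shown sits.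

Going by these compounds, whether the modest step belongs to thiophen-2-yl itself or would also appear with another ring such as phenyl or furan-2-yl stays open. Also open, on these data alone, is whether a methoxy group, a chlorine atom or a carboxylic acid at this position would stay with amino and methyl or move the number in either direction.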